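Swapping the halogenated phenyl on the amide-type nitrogen

The source may report more compounds than this note shows. Statements on the series, on what has been measured and on what is new or still open speak of the compounds shown alone.

Measured so far in a functional assay on RT-112 cells (Homo sapiens) for antiproliferative activity, read by MTT assay, with a stated time of 72 h; a lower number here means a stronger inhibitor of growth, a higher number a weaker inhibitor of growth:
- compound 1 `COc1cc(Nc2ncnc3c(NC(=O)Nc4cccc(Cl)c4Cl)cccc23)cc(OC)c1` gives 63.2 nM
- compound 2 `COc1cc(Nc2ncnc3c(NC(=O)Nc4ccc(Cl)cc4)cccc23)cc(OC)c1` gives 2490 nM
- compound 3 `COc1cc(Nc2ncnc3c(NC(=O)Nc4ccc(Cl)cc4Cl)cccc23)cc(OC)c1` gives 3060 nM

Compound 1 has the lowest number of the three and is therefore the strongest growth inhibitor here; compound 2 is nearest to it and compound 3 furthest, and both of those gaps lie beyond the scatter. Compound 4 `COc1cc(Nc2ncnc3c(NC(=O)Nc4ccc(F)cc4F)cccc23)cc(OC)c1` has not yet been measured. It differs from compound 1 in one place: 2,4-difluorophenyl in place of 2,3-dichlorophenyl on an amide-type nitrogen. Among the compounds with values here, two measured steps bear on this change, since each also replaces the 2,3-dichlorophenyl on the same nitrogen: a 39-fold higher number from compound 1 to compound 2 (1.60 log units; beyond the scatter) and a 48-fold higher number from compound 1 to compound 3 (1.69 log units; beyond the scatter). Both are large losses of potency. Compound 3 carries a 2,4-dichlorophenyl, differing from the 2,4-difluorophenyl of compound 4 only in the halogen, and the comparison a 1.2-fold higher number from compound 2 to compound 3 (0.09 log units; within the scatter) shows that the second chlorine by itself changed little. A large upward step in this assay is therefore expected for compound 4, roughly a 32-fold higher number from compound 1 to compound 4 (1.50 log units; beyond the scatter). The estimated value for compound 4 is 2000 nM, within a range of 500 nM to 8000 nM.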

Compound 4, concentration for 50% growth inhibition: 2460 nM
Estimate against measurement, compound 4: 1.2-fold (0.09 log units) below, and the stated range covers the measured number.
By their numbers in this assay, from the lowest: compound 1; then compounds 4, 2 and 3 (each within the scatter of the next).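

Exchanging the chlorines of the 2,4-dichlorophenyl for fluorines does not bring back the potency of compound 1: a 39-fold higher number from compound 1 to compound 4 (1.59 log units; beyond the scatter) is a large loss, of the same order as the two earlier ones. The halogen itself makes no difference that can be read here, as a 1.2-fold lower number from compound 3 to compound 4 (0.09 log units; within the scatter) shows, and the 2,4-difluorophenyl also matches the 4-chlorophenyl, with a 1.0-fold lower number from compound 2 to compound 4 (0.01 log units; within the scatter). Of the four groups on this nitrogen, only the 2,3-dichlorophenyl stands apart, and no measurement here explains why.

The compounds shown leave open whether a 2,3-difluorophenyl would keep the potency of compound 1, or whether it depends on chlorine. They also leave open how a 2,3-dimethylphenyl or a 3-chlorophenyl would behave on this nitrogen.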